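The source may report more compounds than this note shows. Statements on the series, on what has been measured and on what is new or still open speak of the compounds shown alone.

Measured so far in an ADME assay on L02 cells (Homo sapiens) for antiproliferative activity, read by MTT assay, with a stated time of 48 h; on this read-out higher numbers stand for weaker inhibition and lower numbers for stronger inhibition:
- compound 1 `COc1ccc(-n2nncc2CN2C(=O)C3(C(C#N)=C(N)Oc4c3c3nc5ccccc5nc3c3ccccc43)c3ccccc32)cc1`: > 50000 nM
- compound 2 `CCOc1ccccc1-n1nncc1CN1C(=O)C2(C(C#N)=C(N)Oc3c2c2nc4ccccc4nc2c2ccccc32)c2ccccc21`: > 50000 nM
- compound 3 `Cc1ccc(-n2nncc2CN2C(=O)C3(C(C#N)=C(N)Oc4c3c3nc5ccccc5nc3c3ccccc43)c3ccccc32)cc1Cl`: > 50000 nM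

The value of compound 1 is a limit of this assay, not a number. The value of compound 2 is likewise a limit. The value of compound 3 is likewise a limit. All three therefore stand at the limit of > 50000 nM in this assay, at which 3 of the 3 values shown sit, and the steps among them are not readable: a step that the two limits leave unreadable from compound 1 to compound 2, a step that the two limits leave unreadable from compound 1 to compound 3, a step that the two limits leave unreadable from compound 2 to compound 3.

Compound 4 `N#CC1=C(N)Oc2c(c3nc4ccccc4nc3c3ccccc23)C12C(=O)N(Cc1cnnn1-c1ccc(Cl)c(Cl)c1)c1ccccc12` differs from compound 1 by 3,4-dichlorophenyl in place of 4-methoxyphenyl on an aromatic nitrogen. The change sits on the same aromatic nitrogen as the measured steps, none of which yields a readable size, so no direction is indicated. Compound 4 is therefore expected to remain at the limit as well, with an estimate of 80000 nM, ranging from 30000 nM to 300000 nM. This amounts to an expected step that the limit leaves unreadable from compound 1 to compound 4.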

Compound 4, half-maximal inhibitory concentration: > 50000 nM
Compound 4: no number, only a limit (the forecaster's own chance of this, stated with the estimate: 85%); the middle value lies beyond the limit too.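

Compound 4 adds no readable step to compound 1, compound 2 or compound 3 in this assay, where all stand at a limit: the limit of > 50000 nM in this assay, at which 4 of the 4 values shown sit.

The compounds shown leave open whether changing the group on this aromatic nitrogen alters inhibition at all.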